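The source may report more compounds than this note shows. Statements on the series, on what has been measured and on what is new or still open speak of the compounds shown alone.

Compound 1 `CCCNc1cc(Oc2c(OC)cc3cc(C#N)ccc3c2OC)nc(Nc2ccc(C#N)cc2)n1`. In an ADME assay on MT4 cells (Homo sapiens) for cytotoxicity, read by MTT assay, with a stated time of 5 days (a lower number here means that less compound is tolerated, a higher number that more compound is tolerated), compound 1 gives > 125000 nM, a limit of the assay rather than a number.
Compound 2 `CCCCNc1cc(Oc2c(OC)cc3cc(C#N)ccc3c2OC)nc(Nc2ccc(C#N)cc2)n1`. In this assay compound 2 gives > 125000 nM, again a limit.
Compound 3 `COc1cc2cc(C#N)ccc2c(OC)c1Oc1cc(NC(C)(C)C)nc(Nc2ccc(C#N)cc2)n1`. In this assay compound 3 gives > 125000 nM, likewise a limit.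

Compound 2 therefore stands at the limit of this assay, and the two other values shown stand there with it, as the limit of > 125000 nM in this assay, at which 3 of the 3 values shown sit, records. Within the data shown here, none of the measured steps has a readable size: a step that the two limits leave unreadable from compound 1 to compound 2, a step that the two limits leave unreadable from compound 1 to compound 3 and a step that the two limits leave unreadable from compound 2 to compound 3 all run from one limit to another. Compound 4 `COc1cc2cc(C#N)ccc2c(OC)c1Oc1cc(NC2CCCC2)nc(Nc2ccc(C#N)cc2)n1` differs from compound 2 by cyclopentyl in place of butyl on a nitrogen on an aromatic ring. The closest comparisons are the two steps that also change the group on that nitrogen, to tert-butyl from propyl and from butyl, and both left the value at the limit. Among the measured compounds shown here, compound 4 is therefore expected to remain at the limit as well, and a step that the limit leaves unreadable from compound 2 to compound 4 is estimated as no step that the assay could read. For compound 4 the estimate is 200000 nM, within a range from 100000 nM to 500000 nM.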

Compound 4, half-maximal cytotoxic concentration: > 125000 nM
Compound 4: a limit, no number; the forecaster's own chance of this, stated with the estimate: 85%; the middle value is on the limit's open side.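

In this assay compound 4 gives > 125000 nM, a limit. No step from compound 1, compound 2 or compound 3 to compound 4 can be read: the limit of > 125000 nM in this assay, at which 4 of the 4 values shown sit.

The compounds shown leave open whether the groups on that nitrogen differ at all in this assay, and at what concentration, if any, compound 1, compound 2, compound 3 and compound 4 become cytotoxic.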